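A Fluorine Swap on the Aryl Ring of Compound 3

A few compounds are considered here, and "the series" means these few. Any claim that something is new, unique, unknown or untested is made for them only; others in the source may bear on it.

Three compounds have so far been examined in a functional assay on the whole organism with Mus musculus as the target, in the maximal electroshock model; a lower number here means that less compound is needed, a higher number that more compound is needed for the effect. Compound 1 `FC(F)(F)c1ccc(N2N=NCC2c2ccncc2)cc1` gives 689 mg/kg, compound 2 `COc1ccc(-n2nncc2-c2ccncc2)cc1` gives 311 mg/kg, and compound 3 `c1ccc(-n2nncc2-c2cccnc2)cc1` gives 76.4 mg/kg. Compound 3 therefore stands at the lowest number of the three; its nearest neighbour, compound 2, lies at a higher number beyond the usual scatter, and compound 1 lies further still, also beyond the scatter.

Compound 4 `Fc1ccc(-n2nncc2-c2cccnc2)cc1` has not yet been measured. It differs from compound 3 in one place only: fluoro in place of hydrogen on an aromatic carbon, on an aromatic carbon of a six-membered aromatic ring of carbon only, para to a large group. For the measured compounds named here, no pair of measured compounds differs by exactly this change, so no measured step can guide the expectation directly. Only one heavy atom enters, with no hydrogen-bond donor or acceptor and no net charge, and in this assay the expected step is a 1.1-fold lower number from compound 3 to compound 4 (0.04 log units; within the scatter), which is not expected to reach beyond the scatter in either direction. Compound 4 is accordingly estimated at 70 mg/kg in this assay, with a range from 35 mg/kg to 150 mg/kg.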

Compound 4, dose for half-maximal effect: 74.6 mg/kg
Compound 4: the middle estimate sits 1.1-fold (0.03 log units) below what was measured, and the stated range covers the measured number.
By their numbers in this assay, from the lowest: compounds 4 and 3 (each within the scatter of the next); then compound 2; then compound 1.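

Fluoro in place of hydrogen on an aromatic carbon, para to a large group, gives the first comparison here between two compounds that differ in one place only: in this assay the step is a 1.0-fold lower number from compound 3 to compound 4 (0.01 log units; within the scatter). For the compounds shown here, this position on the six-membered aromatic ring of carbon only therefore accepts one fluorine with no change that can be told from the scatter, something the earlier compounds could not show, since no two of them differed by a single change. The measurements shown offer no explanation for how flat this step is.

As far as these compounds go, what an amine, a carboxylic acid or a longer chain would do on this same aromatic carbon remains open, so one flat step says nothing yet about how far this position would accept other groups. Also open, from the compounds shown here alone, is whether the same fluoro swap would read the same way on the core of compound 1 or of compound 2, as each of these differs from compound 3 in more than one place and neither comes with a partner differing by this single change.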